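This account rests on a few compounds, and the source may have more. Where it says the series, first, only, none or still open, it means among the compounds named here.

Measured so far:
compound 1 `CCc1cnc(N2CCC(c3coc4c(N5CCc6cc(S(C)(=O)=O)ccc65)ncnc34)CC2)nc1` — 154%
compound 2 `CC(=O)c1cnc(N2CCC(c3coc4c(N5CCc6cc(S(C)(=O)=O)ccc65)ncnc34)CC2)nc1` — 12%
compound 3 `CC(O)c1cnc(N2CCC(c3coc4c(N5CCc6cc(S(C)(=O)=O)ccc65)ncnc34)CC2)nc1` — 33%

In a functional assay on cells for agonist activity at Glucose-dependent insulinotropic receptor (Homo sapiens), read by a luciferase reporter, with a stated time of 4 h (on this read-out lower numbers stand for smaller maximal responses and higher numbers for larger maximal responses), compound 3 stands second highest of the three numbers, with compound 2 nearest and compound 1 furthest. Compound 4 `CC(C)(C)OC(=O)N1CCC(c2coc3c(N4CCc5cc(S(C)(=O)=O)ccc54)ncnc23)CC1` differs from compound 3 in one place: tert-butoxycarbonyl in place of 5-(1-hydroxyethyl)pyrimidin-2-yl on an amine nitrogen in a ring. Within the data shown here, no measured step exchanges this whole group; the known steps only change the substituent on the pyrimidine ring, as in a number 121 percentage points lower from compound 1 to compound 3 (beyond the scatter) and a number 21 percentage points higher from compound 2 to compound 3 (beyond the scatter). Since the hydrogen-bond donor that marked compound 3 leaves, the direction is uncertain, and a step of moderate size either way in this assay seems plausible. Compound 4 is therefore expected to give 50%, somewhere between 5% and 140%, which would mean an estimated step of a number 17 percentage points higher from compound 3 to compound 4 (beyond the scatter).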

Compound 4, largest response reached (Emax), in percent of the reference or control that the assay uses: 123%
For compound 4 the middle estimate is 73 percentage points below the measured one; the range from low to high includes it.
By their numbers in this assay, from the lowest: compound 2; then compound 3; then compound 4; then compound 1.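

In this assay the step of a number 90 percentage points higher from compound 3 to compound 4 (beyond the scatter) and the step of a number 111 percentage points higher from compound 2 to compound 4 (beyond the scatter) show that a large response is possible with no aromatic ring on this amine nitrogen, although the step of a number 31 percentage points lower from compound 1 to compound 4 (beyond the scatter) leaves tert-butoxycarbonyl short of 5-ethylpyrimidin-2-yl. The low responses of compound 2 and compound 3 therefore go with their pyrimidine substituents and not with the shared core. Nothing available explains these differences.

Still open, from the compounds shown here alone, is whether a small acetyl or methyl group on this nitrogen keeps the response, and whether a longer chain such as propyl on the pyrimidine ring matches the ethyl of compound 1.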